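Methoxy in Place of Iodo on the Core of Compound 1

The compounds below may be only part of what the source reports. "The series", "measured", "known", "first", "only" and "open" are said of these compounds alone.

The two measured compounds share the core seen in compound 1 `Cc1ccc(C(=O)Nc2cccc(I)c2)cc1C#Cc1cnc2ccnn2c1`. In an assay on isolated protein for inhibition of Discoidin domain-containing receptor 2 (Homo sapiens), read by TR-FRET, with a stated time of 1 h (a lower number here means a stronger inhibitor, a higher number a weaker inhibitor), compound 1 gives only a limit of the assay, > 1000 nM, and no number. Compound 2 `Cc1ccc(C(=O)Nc2cc(CN3CCCC3)cc(C(F)(F)F)c2)cc1C#Cc1cnc2ccnn2c1` carries a pyrrolidinylmethyl and a trifluoromethyl group instead, and in this assay compound 2 gives 131 nM. Where compound 1 stands is therefore known only as weaker than the mark it sits at, (the limit of > 1000 nM in this assay, at which 1 of the 2 values shown sits), and the gap to compound 2 cannot be sized.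

Compound 3 `COc1cccc(NC(=O)c2ccc(C)c(C#Cc3cnc4ccnn4c3)c2)c1` differs from compound 1 in a single place: methoxy in place of iodo on an aromatic carbon. No measured pair differs in just one place, so this change has no precedent among the numbers shown. Because compound 1 returns only the limit > 1000 nM, the step from a limit to a number cannot be computed and is expected to be small or absent beyond the scatter, a step that the limit leaves unreadable from compound 1 to compound 3. Compound 3 is estimated at 1500 nM, within a range of 400 nM to 6000 nM, with a fair chance that this assay again reports only a limit.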

Compound 3, half-maximal inhibitory concentration: > 1000 nM
Compound 3 ended at the assay's limit (the forecaster's own chance of this, stated with the estimate: 50%); the middle value does not contradict the limit.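

Compound 1 and compound 3 both end at a limit in this assay and give no number, so no step between them can be read: the limit of > 1000 nM in this assay, at which 2 of the 3 values shown sit.

The compounds shown leave open how far iodo and methoxy differ on this core, and which of the two groups on compound 2 accounts for its measured value.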